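The compounds below may be only part of what the source reports. "The series", "measured", "known", "first", "only" and "open" are said of these compounds alone.

Among the compounds with values here, in an ADME assay on BHK-21 cells (Mesocricetus auratus) for cytotoxicity, read by MTT assay (on this read-out higher numbers stand for lower toxicity in this test and lower numbers for higher toxicity in this test), compound 1 `CC(=O)c1ccc2c(c1)nc(-c1ccc(C(F)(F)F)cc1)n2C1CCCCC1` gives 33000 nM, the only exact number so far. Compound 2 `COc1ccc(-c2nc3cc(C(C)=O)ccc3n2C2CCCCC2)cc1` gives > 100000 nM, which is a limit of the assay. That single measured step, an at least 3.0-fold higher number from compound 1 to compound 2 (0.48 log units; beyond the scatter), swaps trifluoromethyl for methoxy and leaves the acetyl untouched, so it bears only loosely on compound 3 `C/C(=N\NC(N)=S)c1ccc2c(c1)nc(-c1ccc(C(F)(F)F)cc1)n2C1CCCCC1`. Compound 3 keeps the trifluoromethyl and changes the acetyl site instead: a group of 7 heavy atoms (3 carbon, 3 nitrogen, 1 sulfur; no ring) in place of a group of 3 heavy atoms (2 carbon, 1 oxygen; no ring), on an aromatic carbon. Within the data shown here, no measured step covers this site, so the direction is only a cautious judgement. The expected change is a 2.2-fold lower number from compound 1 to compound 3 (0.34 log units; beyond the scatter), towards higher toxicity. For compound 3 the estimated value is 15000 nM, with an expected range of 4000 nM to 50000 nM.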

Compound 3, half-maximal cytotoxic concentration: > 100000 nM
Compound 3: no number, only a limit; the forecaster's own chance of this, stated with the estimate: 10%; middle value at least 6.6-fold (0.82 log units) from the limit.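

In this assay, putting the larger group in place of the acetyl brings an at least 3.0-fold higher number from compound 1 to compound 3 (0.48 log units; beyond the scatter). This site, which the earlier step left untouched, therefore also moves the read-out, and the move is towards lower toxicity in this test. The result for compound 3 is a limit and not a number, so the true size of the step stays unknown: the limit of > 100000 nM in this assay, at which 2 of the 3 values shown sit.

The compounds shown leave open which part of the new group carries this change, the sulfur or the nitrogens. They also leave open whether a simple amine or a carboxylic acid on this aromatic carbon would move the read-out the same way.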